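Fluoro in place of hydrogen on the core of compound 1

This account rests on a few compounds, and the source may have more. Where it says the series, first, only, none or still open, it means among the compounds named here.

Measured so far:
compound 1 `Fc1cccc(F)c1C#Cc1cnc2ccccc2c1`: 90.4%
compound 2 `Nc1ccc2ncc(C#Cc3c(F)cccc3F)cc2c1`: 9.2%

In a functional assay on LS174T cells (Homo sapiens) for inhibition, with a stated time of 4 days, tested at 10 uM (a lower number here means a weaker effect, a higher number a stronger effect of the compound at the concentration tested), compound 1 gives 90.4%, the highest of the two numbers shown. Compound 2 gives 9.2%. For the measured compounds named here, the only step between measured compounds is a number 81.2 percentage points lower from compound 1 to compound 2 (beyond the scatter), amino in place of hydrogen on an aromatic carbon.

Compound 3 `Fc1ccc2cc(C#Cc3c(F)cccc3F)cnc2c1` is not yet measured. It differs from compound 1 by fluoro in place of hydrogen on an aromatic carbon. Going by the values given here, the one measured step bears on it only loosely, since there the group that enters is amino, here it is fluoro, both on an aromatic carbon of the shared core. Among the compounds with values here, no measured step shows fluoro entering anywhere. With so little to go on, a step no larger than the scatter, or a modest fall, is expected from compound 1 to compound 3, a number 10.4 percentage points lower from compound 1 to compound 3 (beyond the scatter). Compound 3 is therefore estimated at 80%, within 45% to 95%.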

Compound 3, a percentage reported as inhibition, at one concentration (the size of the read-out at that concentration, not a potency): 95.1%
For compound 3 the middle estimate is 15.1 percentage points below the measured one; measured number outside the range, above it.
By their numbers in this assay, from the lowest: compound 2; then compounds 1 and 3 (each within the scatter of the next).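

In this assay, the step for fluoro in place of hydrogen on an aromatic carbon of the shared core is a number 4.7 percentage points higher from compound 1 to compound 3 (within the scatter), so this change on the six-membered aromatic ring of carbon only is tolerated at the concentration tested. For the compounds shown here, until now the only step was a number 81.2 percentage points lower from compound 1 to compound 2 (beyond the scatter), with amino entering, so a substituent on the core does not by itself bring a large fall in this read-out. Nothing available accounts for the difference between the fluoro and amino steps.

From the compounds shown here alone, it remains open whether a larger group at this place, such as methoxy or a nitrile, is tolerated as well as fluoro, and whether fluoro gives the same result on other carbons of the core. A read-out at one concentration also gives no potency for compound 1 or compound 3.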